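Swapping a halogen around the benzyl ring

A few compounds are considered here, and "the series" means these few. Any claim that something is new, unique, unknown or untested is made for them only; others in the source may bear on it.

Of the compounds shown here, three sharing one core have been tested in a functional assay on MGC-803 cells (Homo sapiens) for inhibition, read by MTT assay, with a stated time of 72 h; a lower number here means a stronger inhibitor, a higher number a weaker inhibitor. Compound 1 `Cc1cc(Nc2cc(-c3ccccc3)[nH]n2)n2nc(SCCCc3ccccc3)nc2n1` gives 6510 nM, compound 2 `Cc1cc(Nc2cc(-c3ccccc3)[nH]n2)n2nc(SCc3c(Cl)cccc3Cl)nc2n1` gives 5280 nM, and compound 3 `Cc1cc(Nc2cc(-c3ccccc3)[nH]n2)n2nc(SCc3ccc(F)cc3)nc2n1` gives 3270 nM. These three differ only in the group on a saturated chain carbon bound to a sulfur: phenethyl, 2,6-dichlorophenyl or 4-fluorophenyl. The steps between them are all small: a 1.2-fold lower number from compound 1 to compound 2 (0.09 log units; within the scatter), a 2.0-fold lower number from compound 1 to compound 3 (0.30 log units; within the scatter) and a 1.6-fold lower number from compound 2 to compound 3 (0.21 log units; within the scatter). Compound 3 therefore cannot be separated from the other two; the three numbers stand level within the scatter.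

Compound 4 `Cc1cc(Nc2cc(-c3ccccc3)[nH]n2)n2nc(SCc3ccccc3Br)nc2n1` has not yet been measured in this assay. It differs from compound 3 in one place: 2-bromophenyl in place of 4-fluorophenyl on a saturated chain carbon bound to a sulfur. For the measured compounds named here, the steps that bear on this change are those reaching compound 3, a 2.0-fold lower number from compound 1 to compound 3 (0.30 log units; within the scatter) and a 1.6-fold lower number from compound 2 to compound 3 (0.21 log units; within the scatter), both within the scatter, and the one between the two halogenated groups, a 1.6-fold lower number from compound 2 to compound 3 (0.21 log units; within the scatter), also within the scatter. Going by the values given here, nothing among the measured compounds suggests that the 2-bromophenyl group will move the number beyond the scatter, so a step of a 1.3-fold higher number from compound 3 to compound 4 (0.11 log units; within the scatter) is expected. Compound 4 is therefore estimated to give 4200 nM in this assay, with a range from 2000 nM to 9000 nM.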

Compound 4, half-maximal inhibitory concentration: 3650 nM
Compound 4: the middle estimate sits 1.2-fold (0.06 log units) above what was measured; low and high end bracket the measured number.
By their numbers in this assay, from the lowest: compounds 3, 4, 2 and 1 (each within the scatter of the next).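

Putting 2-bromophenyl in place of 4-fluorophenyl alters both the halogen and its number on the ring, yet this assay shows only a 1.1-fold higher number from compound 3 to compound 4 (0.05 log units; within the scatter). The new group also stands level with the other two, with a 1.4-fold lower number from compound 2 to compound 4 (0.16 log units; within the scatter) and a 1.8-fold lower number from compound 1 to compound 4 (0.25 log units; within the scatter), so four different groups on a saturated chain carbon bound to a sulfur now give numbers that cannot be told apart. Nothing measured here accounts for how close these numbers lie.

From the compounds shown here alone, all four groups end in a phenyl ring, so it remains open whether a group without that ring, such as an amine, a carboxylic acid or a plain alkyl chain, would move the number beyond the scatter. The identity of the halogen and its number on the ring also remain tied together in this comparison, and a pair such as 2-fluorophenyl and 4-bromophenyl would be needed to pull the two apart.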